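Cytotoxicity of two cyanobenzyl analogues and a methyl ester

A few compounds are considered here, and "the series" means these few. Any claim that something is new, unique, unknown or untested is made for them only; others in the source may bear on it.

Compound 1, `CCOC(=O)c1cnc(N2CCN(Cc3ccc(C#N)cc3)CC2)nc1Oc1c(C)cc(-c2ccc(C#N)cc2)cc1C`, gives > 125000 nM in an ADME assay on MT4 cells (Homo sapiens) for cytotoxicity, read by MTT assay, with a stated time of 4 days (on this read-out higher numbers stand for lower toxicity in this test and lower numbers for higher toxicity in this test), which is a limit of the assay.
Compound 2, `CCOC(=O)c1cnc(N2CCN(Cc3cccc(C#N)c3)CC2)nc1Oc1c(C)cc(-c2ccc(C#N)cc2)cc1C`, gives > 125000 nM in this assay, again a limit of the assay.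

The step that the two limits leave unreadable from compound 1 to compound 2 cannot be read because of the limit of > 125000 nM in this assay, at which 2 of the 2 values shown sit. Compound 3, `CCOC(=O)c1cnc(N2CCN(Cc3cccc(C(=O)OC)c3)CC2)nc1Oc1c(C)cc(-c2ccc(C#N)cc2)cc1C`, is not yet measured; it differs from compound 2 by methoxycarbonyl in place of cyano on an aromatic carbon. Within the data shown here, no measured step speaks to that change, so nothing beyond the scatter is foreseen. The expected step is a step that the limit leaves unreadable from compound 2 to compound 3. Compound 3 is therefore estimated at 150000 nM, between 40000 nM and 500000 nM, most likely reported only as a limit.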

Compound 3, half-maximal cytotoxic concentration: > 125000 nM
Compound 3: no number, only a limit; the forecaster's own chance of this, stated with the estimate: 75%; the middle value is on the limit's open side.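

No step among compound 1, compound 2 and compound 3 can be read, because each value is a limit of the assay: the limit of > 125000 nM in this assay, at which 3 of the 3 values shown sit.

The compounds shown leave open where the actual cytotoxic concentration of each lies in this assay, and so whether exchanging these groups changes it at all.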